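From 3-Methylphenyl to 2-Fluorophenyl: An Expected Tolerance

The source may report more compounds than this note shows. Statements on the series, on what has been measured and on what is new or still open speak of the compounds shown alone.

In a toxicity assay on HaCaT cells (Homo sapiens) for cytotoxicity, read by CCK-8 assay, with a stated time of 24 h (a higher number here means that more compound is tolerated, a lower number that less compound is tolerated), compound 1 (`COc1ccccc1Oc1c(N)nc(-c2cccc(C)c2)nc1Cl`) gives 11200 nM and compound 2 (`COc1ccc(-c2nc(N)c(Oc3ccccc3OC)c(Cl)n2)cc1`) gives 8200 nM as its reading. For the measured compounds named here, these are the only two numbers available and they do not separate, so compound 1 stands level with its single neighbour. Compound 3 (`COc1ccccc1Oc1c(N)nc(-c2ccccc2F)nc1Cl`) has not yet been measured. It keeps the core of compound 1 and carries 2-fluorophenyl in place of 3-methylphenyl on an aromatic carbon, a change counted as 2-fluorophenyl in place of 3-methylphenyl on an aromatic carbon and confined to that one place. Going by the values given here, only one measured step bears on it, the replacement of 3-methylphenyl at the same place by 4-methoxyphenyl, which gave a 1.4-fold lower number from compound 1 to compound 2 (0.14 log units; within the scatter) as its result. That single step is thin evidence, and neither measured compound carries fluorine, but it gives no reason to expect a shift beyond the scatter in either direction. The expected outcome is a 1.2-fold lower number from compound 1 to compound 3 (0.07 log units; within the scatter) on this estimate. Compound 3 is estimated at 9500 nM with an expected range from 4500 nM to 20000 nM once it is measured.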

Compound 3, half-maximal cytotoxic concentration: > 80000 nM
Compound 3: a limit, no number; the forecaster's own chance of this, stated with the estimate: 5%; at least 8.4-fold (0.92 log units) between middle value and limit.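

The earlier step, a 1.4-fold lower number from compound 1 to compound 2 (0.14 log units; within the scatter), left this place looking quiet in this assay, but the new steps show that the aryl group on this aromatic carbon, between two ring nitrogen atoms, can change the reading well beyond the scatter: with 2-fluorophenyl in place of 3-methylphenyl there is an at least 7.1-fold higher number from compound 1 to compound 3 (0.85 log units; beyond the scatter), and with 2-fluorophenyl in place of 4-methoxyphenyl there is an at least 9.7-fold higher number from compound 2 to compound 3 (0.98 log units; beyond the scatter). The groups exchanged have the same count of heavy atoms, and each is one six-membered aromatic ring of carbon only, so these counts do not separate 2-fluorophenyl from 3-methylphenyl, even though the readings differ. The reading of compound 3 is a limit and not a number: the limit of > 80000 nM in this assay, at which 1 of the 3 values shown sits.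

A 2-methylphenyl or a 4-fluorophenyl group at this place would help to tell whether the change follows the fluorine, the place of the substituent on the phenyl ring, or both together. Going by these compounds, it also remains open how a non-aromatic group at this carbon, such as a morpholine or a simple amine, would read in this assay.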